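The source may report more compounds than this note shows. Statements on the series, on what has been measured and on what is new or still open speak of the compounds shown alone.

Measured compounds in a functional assay on Ishikawa cells (Homo sapiens) for antiproliferative activity, read by CCK-8 assay, with a stated time of 48 h; on this read-out lower numbers stand for stronger inhibition and higher numbers for weaker inhibition:
compound 1 `C=CC(=O)NCCOc1ccc(Oc2c(-c3ccc(F)cc3)sc3cc(O)ccc23)cc1` gives > 25000 nM, which is a limit of the assay and not a number.
compound 2 `C=C(C)C(=O)NCCOc1ccc(Oc2c(-c3ccc(F)cc3)sc3cc(O)ccc23)cc1` gives > 25000 nM, again a limit of the assay rather than a number.
compound 3 `C=CC(=O)N1CC(Oc2ccc(Oc3c(-c4ccc(F)cc4)sc4cc(O)ccc34)cc2)C1` gives 12300 nM, the only plain number in the set.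

Compound 1 and compound 2 share one core, while compound 3 carries a different one: 1-(vinylcarbonyl)azetidin-3-yl in place of 2-((vinylcarbonyl)amino)ethyl on an oxygen on an aromatic ring. That change brings an at least 2.0-fold lower number from compound 1 to compound 3 (0.30 log units; that floor lies within the scatter) and an at least 2.0-fold lower number from compound 2 to compound 3 (0.30 log units; that floor lies within the scatter). The small change methyl in place of hydrogen on a double-bonded chain carbon bound to a carbonyl carbon sits at exactly the same place as methyl in place of hydrogen on a double-bonded chain carbon bound to a carbonyl carbon, which turns compound 3 into compound 4 `C=C(C)C(=O)N1CC(Oc2ccc(Oc3c(-c4ccc(F)cc4)sc4cc(O)ccc34)cc2)C1`, so it is the same change. Measured once, it gave a step that the two limits leave unreadable from compound 1 to compound 2, because both values rest at the limit of > 25000 nM in this assay, at which 2 of the 3 values shown sit. Beside that unreadable step, the step expected this time is a 1.2-fold higher number from compound 3 to compound 4 (0.09 log units; within the scatter), kept small since nothing shows the methyl helping or hurting. Compound 4 is therefore estimated at 15000 nM, within 5000 nM to 40000 nM.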

Compound 4, half-maximal inhibitory concentration: 14200 nM
Beside the measured number, compound 4's estimate is 1.1-fold (0.02 log units) above it; the range from low to high includes it.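

In this assay, methyl in place of hydrogen on a double-bonded chain carbon bound to a carbonyl carbon gives a 1.2-fold higher number from compound 3 to compound 4 (0.06 log units; within the scatter), so on this core the change leaves the number within the scatter. On the core of compound 1 and compound 2 the same change, like any step between those two compounds, cannot be read, because both values are limits and not numbers: the limit of > 25000 nM in this assay, at which 2 of the 4 values shown sit. The floors an at least 1.7-fold lower number from compound 2 to compound 4 (0.24 log units; that floor lies within the scatter) and an at least 1.7-fold lower number from compound 1 to compound 4 (0.24 log units; that floor lies within the scatter) also lie within the scatter, so the series does not show whether the methyl behaves alike on both cores.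

Going by these compounds, it remains open how the number would respond to an ethyl group or an amine on that same chain carbon. Also open, on these data alone, is whether a longer chain on the oxygen would bring the core of compound 1 to a readable value.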